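Swapping methoxy for chloro on the thiourea aryl ring

This account rests on a few compounds, and the source may have more. Where it says the series, first, only, none or still open, it means among the compounds named here.

Measured compounds:
- compound 1, `COc1cccc(NC(=S)NC2CC(C)(C)Oc3ccc(Br)cc32)c1`: "not determined" (no result reported)
- compound 2, `CC1(C)CC(NC(=O)Nc2ccc(Cl)cc2)c2cc(Br)ccc2O1`: 9000 nM

The two compounds share the same core and differ in the linker and in the substituent on the outer aromatic ring. In a functional assay on B16-F10 cells (Mus musculus) for inhibition, read by MTT assay, with a stated time of 72 h (on this read-out lower numbers stand for stronger inhibition and higher numbers for weaker inhibition), compound 2 gives 9000 nM. In this assay compound 1 gives "not determined" (no result reported), so compound 1 stands nowhere on these numbers and there is no starting value from which a step could be measured.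

The new compound, compound 3, `CC1(C)CC(NC(=S)Nc2cccc(Cl)c2)c2cc(Br)ccc2O1`, keeps the thiourea linker of compound 1 and differs from it in one place: chloro in place of methoxy on an aromatic carbon. With no number for compound 1, no size or direction can be assigned to this step in this assay; whatever change it brings cannot be told apart from the scatter on the data shown. Among the compounds with values here, the only anchor is compound 2, whose value in this assay is 9000 nM.

Compound 3 is therefore expected to give about 8000 nM in this assay, with a plausible range from 2000 nM to 30000 nM.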

Compound 3, half-maximal inhibitory concentration: 7000 nM
Compound 3: middle estimate off by 1.1-fold (0.06 log units), on the high side; measured number inside the range.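

In this assay, within the data shown here, compound 1 gives "not determined" (no result reported), so no step from compound 1 to compound 3 can be read. The compounds shown leave open whether replacing 3-methoxyphenyl with 3-chlorophenyl changes inhibition in this assay at all. Nothing shown offers an explanation for the value of compound 3.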